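The source may hold more compounds than are shown below. What is called first, only, known or untested is meant among the compounds shown, and "the series" means these compounds.

Compound 1, `CC(C)CSc1nc(N)nc2c1ncn2/C=C1/CC1(CO)CO`, in an ADME assay on Akata cells (Homo sapiens) for cytotoxicity, with a stated time of 7 days (on this read-out lower numbers stand for higher toxicity in this test and higher numbers for lower toxicity in this test), gives > 20000 nM, a limit of this assay rather than a number.
Compound 2, `CCCCCOc1nc(N)nc2c1ncn2/C=C1/CC1(CO)CO`, in this assay gives > 20000 nM, again a limit and not a number.
Compound 3, `Nc1nc(NC2CCCC2)c2ncn(/C=C3/CC3(CO)CO)c2n1`, in this assay gives > 20000 nM, also a limit and not a number.

Compound 1 therefore stands only at a limit in this assay, and the two other values shown sit at the same limit, which is the content of the limit of > 20000 nM in this assay, at which 3 of the 3 values shown sit. The step that the two limits leave unreadable from compound 1 to compound 2, the step that the two limits leave unreadable from compound 1 to compound 3 and the step that the two limits leave unreadable from compound 2 to compound 3 are all unreadable: each exchanges one group on an aromatic carbon of the shared core, and in each case both ends sit at the limit, so no size can be read.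

Compound 4, `CSc1nc(N)nc2c1ncn2/C=C1/CC1(CO)CO`, has not been measured in this assay. It differs from compound 1 by hydrogen in place of isopropyl on a saturated chain carbon bound to a sulfur. None of the three measured steps touches this group or bears on it directly; all three change a different attachment on the core and all three leave the limit untouched. With every value in the set at the limit, there is no evidence of a readable step in either direction.

For compound 4 the expected step from compound 1 is a number no higher from compound 1 to compound 4 (the limit leaves the size open), that is none beyond the scatter. Compound 4 is accordingly estimated at 20000 nM, within 10000 nM to 100000 nM, most likely reported again as a limit.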

Compound 4, half-maximal cytotoxic concentration: > 20000 nM
Compound 4: only a limit was reported; the forecaster's own chance of this, stated with the estimate: 85%; the middle value lies on the limit itself.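

With compound 4, no new step can be read against compound 1, compound 2 or compound 3 in this assay, because all four compounds stop at the same limit: the limit of > 20000 nM in this assay, at which 4 of the 4 values shown sit.

The compounds shown leave open whether the isobutylsulfanyl, methylsulfanyl, pentyloxy and cyclopentylamino compounds differ at all in their toxicity in this test.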